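This account rests on a few compounds, and the source may have more. Where it says the series, first, only, none or still open, it means among the compounds named here.

Compound 1 `COc1cc2nc(/C=C/c3ccccn3)nc(N3CCC(CCNS(N)(=O)=O)CC3)c2cc1OC` and compound 2 `COc1cc2nc(/C=C/c3ccc(F)cc3)nc(N3CCC(CCNS(N)(=O)=O)CC3)c2cc1OC` share the same core and differ in one place, the aromatic ring carried on the double-bonded chain. In an assay on cells for inhibition of Ectonucleotide pyrophosphatase/phosphodiesterase family member 1 (Homo sapiens), with a stated time of 60 min, tested at 1 uM (a higher number here means more inhibition at the concentration tested (going by the name of the read-out), a lower number less inhibition), compound 1 gives 85%, while compound 2 gives 70%. Among the compounds with values here, compound 2 therefore holds the lower of the two numbers so far, with compound 1 its only neighbour, and the gap between them is a number 15 percentage points lower from compound 1 to compound 2 (beyond the scatter). Compound 3 `COc1ccc(/C=C/c2nc(N3CCC(CCNS(N)(=O)=O)CC3)c3cc(OC)c(OC)cc3n2)cc1` has not yet been measured. It differs from compound 2 in a single spot: methoxy in place of fluoro on an aromatic carbon. Within the data shown here, the one measured step exchanges a whole ring, pyridin-2-yl for 4-fluorophenyl, and so says nothing about trading a fluoro for a methoxy on an aromatic carbon; no measured step bears directly on this change. With nothing to point either way, the expectation is a step that stays within the scatter, in either direction, no change at the digits printed from compound 2 to compound 3 (within the scatter). Compound 3 is estimated at 70%, with a range from 50% to 85%.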

Compound 3, a percentage reported as inhibition, at one concentration (the size of the read-out at that concentration, not a potency): 66%
For compound 3 the middle estimate is 4 percentage points above the measured one; measured number inside the range.
By their numbers in this assay, from the lowest: compounds 3 and 2 (each within the scatter of the next); then compound 1.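

In this assay, trading fluoro for methoxy on the aromatic carbon para to a large group gives a number 4 percentage points lower from compound 2 to compound 3 (within the scatter), so this position accepts a group of 2 heavy atoms with 1 hydrogen-bond acceptor in place of a single fluorine with none, and the read-out stays within the usual spread of repeat measurements. The comparison with the pyridine compound gives a number 19 percentage points lower from compound 1 to compound 3 (beyond the scatter), which matches the earlier step of a number 15 percentage points lower from compound 1 to compound 2 (beyond the scatter): both para-substituted phenyl compounds sit beyond the scatter under compound 1, and neither goes against this pattern among the three compounds. No independent measurement accompanies these numbers that could explain either step.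

The compounds shown leave open whether this para position would stay as undemanding with an amine, a carboxylic acid or a longer chain such as butoxy, since fluoro and methoxy are only two examples. They also leave open how a plain phenyl ring, with hydrogen on that carbon, would compare with compound 1, which is the comparison needed to separate the effect of the ring itself from that of its para group.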